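The compounds below may be only part of what the source reports. "The series", "measured", "known", "first", "only" and "open" are said of these compounds alone.

Measured compounds:
compound 1 `CCC(C)NC(=O)/C=C/c1ccccc1`: 56%
compound 2 `C=CCNC(=O)/C=C/c1ccccc1`: 63%

In a functional assay on the whole organism for inhibition, with Brassica rapa subsp. chinensis as the target, with a stated time of 3 days, tested at 100 ppm (on this read-out lower numbers stand for less inhibition of growth and higher numbers for more inhibition of growth at the one concentration tested), compound 2 gives the higher of the two numbers, but the step of a number 7 percentage points higher from compound 1 to compound 2 (within the scatter) is within the scatter, so compound 1 and compound 2 cannot be told apart on this read-out.

Compound 3 `CCCOC(=O)/C=C/c1ccccc1` is not yet measured. It differs from compound 2 as follows: propoxy in place of allylamino on a carbonyl carbon. Among the measured compounds shown here, the one measured step, a number 7 percentage points higher from compound 1 to compound 2 (within the scatter), exchanges one substituent on the amide-type nitrogen for another and leaves the nitrogen itself in place; the change to compound 3 removes the allylamino group altogether and puts propoxy on the carbonyl carbon. For the measured compounds named here, no measured pair shows what such an exchange does in this assay, so the measured step bears on it only indirectly: it shows that varying the group attached to the carbonyl carbon side chain did not move the number beyond the scatter.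

The expectation for compound 3 in this assay is therefore a step of a number 13 percentage points lower from compound 2 to compound 3 (beyond the scatter) of no clear direction, with the range widened for the untested change. The estimate for compound 3 is 50%, expected between 25% and 75%.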

Compound 3, percent growth inhibition at one concentration: 31%
Beside the measured number, compound 3's estimate is 19 percentage points above it; low and high end bracket the measured number.
By their numbers in this assay, from the lowest: compound 3; then compounds 1 and 2 (each within the scatter of the next).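

In this assay the group on the carbonyl carbon turns out to be a place where the number does respond: propoxy in place of allylamino gives a number 32 percentage points lower from compound 2 to compound 3 (beyond the scatter) and propoxy in place of (sec-butyl)amino gives a number 25 percentage points lower from compound 1 to compound 3 (beyond the scatter) in the same direction. The earlier exchange of one substituent on the amide-type nitrogen for another stayed within the scatter, whereas both of these steps lie beyond it, so among these three compounds only compound 3, the one without a nitrogen on the carbonyl carbon, stands apart, and it stands lowest. Nothing available bears on why the number falls with this exchange.

The step from compound 2 to compound 3 changes the linking atom and also loses the double bond outside aromatic rings, so the compounds shown do not separate these two changes; a propylamino or an allyloxy group on the same carbonyl carbon would do so. Also open, on these data alone, is whether the lower number holds for oxygen-linked groups in general, such as a longer butoxy chain or a carboxylic acid at this place.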